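This account rests on a few compounds, and the source may have more. Where it says the series, first, only, none or still open, it means among the compounds named here.

Compounds measured in a functional assay on T47D cells (Homo sapiens) for cytotoxicity, read by MTT assay, with a stated time of 2 days; a lower number here means a stronger inhibitor, a higher number a weaker inhibitor:
compound 1 `Cc1ccc2nc(-c3cccc(OC(F)(F)F)c3)[nH]c(=O)c2c1` — > 50000 nM
compound 2 `CCN(CC)c1ccc2nc(-c3ccccc3N(C)C)[nH]c(=O)c2c1` — 2210 nM
compound 3 `Cc1ccc2nc(-c3ccccc3N(C)C)[nH]c(=O)c2c1` — 26700 nM

Compound 2 gives the lowest of the two numbers shown in this assay. Its nearest neighbour is compound 3, which differs only on the core; that step, a 12-fold higher number from compound 2 to compound 3 (1.08 log units; beyond the scatter), is large. The value of compound 1 in this assay is a limit, not a number (the limit of > 50000 nM in this assay, at which 1 of the 3 values shown sits).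

Compound 4 `CCN(CC)c1ccc2nc(-c3ccccc3C(F)(F)F)[nH]c(=O)c2c1` changes the pendant ring of compound 2 instead: trifluoromethyl in place of dimethylamino on an aromatic carbon. For the measured compounds named here, no measured step alters that ring, so nothing bears directly on this change. Compound 1, which carries a fluorinated group on its pendant ring and differs from compound 3 in more than one place, reaches only the limit. An increase is therefore expected, a 4.5-fold higher number from compound 2 to compound 4 (0.66 log units; beyond the scatter), with compound 4 estimated at 10000 nM (range 3000 nM to 50000 nM).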

Compound 4, half-maximal inhibitory concentration: 2550 nM
Beside the measured number, compound 4's estimate is 3.9-fold (0.59 log units) above it; the whole stated range lies above it.
By their numbers in this assay, from the lowest: compounds 2 and 4 (each within the scatter of the next); then compound 3. At a limit, above all of these: compound 1.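

At this place on the pendant ring, an aromatic carbon ortho to a large group, trifluoromethyl in place of dimethylamino gives a 1.2-fold higher number from compound 2 to compound 4 (0.06 log units; within the scatter), so the two groups cannot be told apart here when diethylamino sits on the core. For the compounds shown here, this is the first direct reading of this ring: dimethylamino can be exchanged without a change beyond the scatter. Nothing shown explains why the two groups match.

On these data alone, whether the same exchange holds with the methyl core of compound 3 stays open. So does the effect of a methoxy group, a carboxylic acid or a primary amine at this place.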